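The source may report more compounds than this note shows. Statements on the series, on what has been measured and on what is new or still open speak of the compounds shown alone.

Compound 1, `COc1cc(Cl)cc(-c2nn(-c3cccc(NC(=O)Nc4ccc(Cl)c(C(F)(F)F)c4)c3)cc2-c2ccncc2)c1`: -48%
Compound 2, `COc1cc(Cl)cc(-c2nn(-c3cccc(NC(=O)Nc4cc(C(F)(F)F)cc(C(F)(F)F)c4)c3)cc2-c2ccncc2)c1`: -60%
Compound 3, `COc1cc(Cl)cc(-c2nn(-c3cccc(NC(=O)Nc4ccc(Cl)c(Cl)c4)c3)cc2-c2ccncc2)c1`: 12%

In a functional assay on HOP-62 cells (Homo sapiens) for inhibition, read by sulforhodamine B assay, with a stated time of 48 h, tested at 100 uM (a lower number here means a stronger effect, a higher number a weaker effect of the compound at the concentration tested), compound 3 gives the highest of these three numbers, that is, the weakest effect, beyond the scatter from both compound 1 and compound 2. Compound 4, `COc1cc(Cl)cc(-c2nn(-c3cccc(NC(=O)Nc4cccc(C(F)(F)F)c4)c3)cc2-c2ccncc2)c1`, differs from compound 3 in one place: 3-(trifluoromethyl)phenyl in place of 3,4-dichlorophenyl on an amide-type nitrogen. Within the data shown here, the one measured step that bears on this is a number 60 percentage points higher from compound 1 to compound 3 (beyond the scatter), which runs the opposite way, chloro in place of trifluoromethyl. Among the measured compounds shown here, compound 4 brings a trifluoromethyl back and at the same time loses a chloro, and no measured pair shows the loss of a chloro alone, so the size is uncertain. A downward step in this assay beyond the scatter is nevertheless expected, a number 42 percentage points lower from compound 3 to compound 4 (beyond the scatter). Compound 4 is estimated at -30%, with a range from -65% to 10%.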

Compound 4, a percentage reported as activity, at one concentration (the size of the read-out at that concentration, not a potency): -41%
Beside the measured number, compound 4's estimate is 11 percentage points above it; the range from low to high includes it.
By their numbers in this assay, from the lowest: compound 2; then compounds 1 and 4 (each within the scatter of the next); then compound 3.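

In this assay, placing 3-(trifluoromethyl)phenyl instead of 3,4-dichlorophenyl on the amide-type nitrogen strengthens the effect by a large margin (a number 53 percentage points lower from compound 3 to compound 4 (beyond the scatter)). Hydrogen in place of chloro leaves the result within the scatter (a number 7 percentage points higher from compound 1 to compound 4 (within the scatter)), whereas hydrogen in place of a second trifluoromethyl weakens the effect modestly (a number 19 percentage points higher from compound 2 to compound 4 (beyond the scatter)). No available evidence explains these differences. The compounds shown leave open how a single chloro, a nitrile or an amine would compare with this trifluoromethyl on the same ring.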